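Enantiomer of the thioether series: compound 4

A few compounds are considered here, and "the series" means these few. Any claim that something is new, unique, unknown or untested is made for them only; others in the source may bear on it.

Measured so far in an assay on isolated protein for inhibition of Retinaldehyde dehydrogenase 3 (Homo sapiens); a higher number here means a weaker inhibitor, a lower number a stronger inhibitor:
compound 1 `C[C@@H](Sc1nc2c(cnn2C)c(=O)n1-c1ccccc1)c1ccccc1` gives 34 nM
compound 2 `CCC(Sc1nc2c(cnn2C)c(=O)n1-c1ccccc1)c1ccccc1` gives 119 nM
compound 3 `CC(Sc1nc2c(cnn2C)c(=O)n1-c1ccccc1)c1ccccc1` gives 73 nM

Compound 3 sits second highest of the three numbers in this assay; its nearest neighbour is compound 2, and the gap to it is within the scatter, while compound 1 lies further off with a lower number.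

Compound 4 `C[C@H](Sc1nc2c(cnn2C)c(=O)n1-c1ccccc1)c1ccccc1` is not yet measured. It differs from compound 3 in this way: the two compounds have the same atoms and bonds; at least one stereo element is drawn with a configuration in one of them and without one in the other: 1 of 1 stereo elements differ; a stereocentre at a saturated chain carbon is drawn without a configuration in compound 3 and S in compound 4. The step that bears on this is a 2.1-fold higher number from compound 1 to compound 3 (0.33 log units; beyond the scatter), a modest rise when the configuration is no longer drawn, which rests on (the fact that one of compounds 1 and 3 is drawn with a defined configuration and the other without, at the place where they differ). Since compound 1 carries the opposite configuration to compound 4, and compound 3 with no drawn configuration already reads higher than compound 1, the other enantiomer is expected to read higher still, beyond the scatter. The steps of a 3.5-fold higher number from compound 1 to compound 2 (0.54 log units; beyond the scatter) and a 1.6-fold lower number from compound 2 to compound 3 (0.21 log units; within the scatter) concern the chain, not the configuration, and do not inform this step. Compound 4 is therefore expected at 200 nM (range 80 nM to 600 nM), meaning an estimated step of a 2.7-fold higher number from compound 3 to compound 4 (0.44 log units; beyond the scatter).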

Compound 4, half-maximal inhibitory concentration: 1640 nM
The estimate for compound 4 lay 8.2-fold (0.91 log units) below the measured number, outside the stated range (above it).
By their numbers in this assay, from the lowest: compound 1; then compounds 3 and 2 (each within the scatter of the next); then compound 4.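

In this assay the stereocentre at a saturated chain carbon now accounts for the widest gap in the series, with a 48-fold higher number from compound 1 to compound 4 (1.68 log units; beyond the scatter) between two compounds that share all atoms and bonds: the fact that compounds 1 and 4 differ only in the configuration as drawn. Compound 3, drawn without a configuration, stands far from the S form, with a 22-fold higher number from compound 3 to compound 4 (1.35 log units; beyond the scatter), and its printed value lies much nearer that of compound 1, the R form: the fact that one of compounds 3 and 4 is drawn with a defined configuration and the other without, at the place where they differ. The step of a 14-fold higher number from compound 2 to compound 4 (1.14 log units; beyond the scatter) changes the chain while setting a drawn S configuration against an undrawn one, so it cannot be read as a chain effect alone.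

Open, on these data alone, is whether the 1-phenylpropyl compound splits between its two configurations as the 1-phenylethyl pair does. Also open, as far as these compounds go, is whether an amine or a carboxylic acid on the phenyl of the 1-phenylethyl group would keep this gap between configurations.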